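The source may hold more compounds than are shown below. What is called first, only, known or untested is meant among the compounds shown, and "the series" means these compounds.

Within the data shown here, compound 2 `c1c[nH]c(CN2CCN(CCCc3c[nH]c4ccc(-n5cnnc5)cc34)CC2)n1` has the highest number of the three compounds measured so far in an assay on CHO cells for displacement of a labelled ligand from 5-hydroxytryptamine receptor 1D (Homo sapiens) (on this read-out lower numbers stand for stronger inhibition and higher numbers for weaker inhibition), where compound 2 gives 1.6 nM. Its nearest neighbour is compound 3 `CN(C)C(=O)C(c1ccccc1)N1CCN(CCCc2c[nH]c3ccc(-n4cnnc4)cc23)CC1`, which in this assay gives 1 nM, a gap within the scatter. The furthest is compound 1 `c1cc(CN2CCN(CCCc3c[nH]c4ccc(-n5cnnc5)cc34)CC2)ccn1`, which in this assay gives 0.6 nM; that gap is beyond the scatter, with a 2.7-fold higher number from compound 1 to compound 2 (0.43 log units; beyond the scatter) when the ring on the chain carbon is exchanged.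

Compound 4 `c1ccc(CCCN2CCN(CCCc3c[nH]c4ccc(-n5cnnc5)cc34)CC2)cc1` is the next step from compound 2: phenethyl in place of 1H-imidazol-2-yl on a saturated chain carbon bound to an amine nitrogen in a ring. Among the measured compounds shown here, only one measured step bears on this position, the one from compound 1 to compound 2, and it is modest. Since compound 4 also carries a six-membered aromatic ring at this place, as compound 1 does with a pyridine, the step is expected to run back toward the number of compound 1, but only modestly. Compound 4 is therefore expected to show a 2.0-fold lower number from compound 2 to compound 4 (0.30 log units; within the scatter), with an estimate of 0.8 nM and a range from 0.3 nM to 2.5 nM.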

Compound 4, half-maximal inhibitory concentration: 4.9 nM
For compound 4 the middle estimate is 6.1-fold (0.79 log units) below the measured one; the measured number lies above the stated range.
By their numbers in this assay, from the lowest: compounds 1, 3 and 2 (each within the scatter of the next, the first and the last beyond it); then compound 4.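

In this assay, replacing (1H-imidazol-2-yl)methyl with 3-phenylpropyl gives a 3.1-fold higher number from compound 2 to compound 4 (0.49 log units; beyond the scatter), while the same group set against the pyridin-4-yl series gives an 8.2-fold higher number from compound 1 to compound 4 (0.91 log units; beyond the scatter), and both steps lie beyond the scatter. Compound 4 carries a six-membered aromatic ring, as compound 1 does, yet its number does not return toward that of compound 1, so among these compounds a six-membered aromatic ring at this place does not by itself give the lower number. Nothing measured here accounts for this shift.

The change lengthens the chain and removes the ring nitrogens at once, so the compounds shown do not separate these two differences. A benzyl group or a 3-(pyridin-4-yl)propyl group at this place would pull them apart.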